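The source may report more compounds than this note shows. Statements on the series, on what has been measured and on what is new or still open speak of the compounds shown alone.

In a functional assay on A549 cells (Homo sapiens) for cytotoxicity, read by MTT assay, with a stated time of 72 h (on this read-out higher numbers stand for weaker inhibition and lower numbers for stronger inhibition), three compounds sharing one core have been measured. Compound 1 `COc1ccc(/C=C2\CCC/C(=C\c3ccccc3Cl)C2=O)cc1OC` reads > 20000 nM, which is a limit of the assay and not a number. Compound 2 `COc1ccc(/C=C2\CCC/C(=C\c3ccc(Cl)cc3)C2=O)cc1OC` gives 10100 nM, and compound 3 `COc1ccc(/C=C2\CCC/C(=C\c3cccc(Br)c3)C2=O)cc1OC` gives 12800 nM. These two values stand close together, with a 1.3-fold higher number from compound 2 to compound 3 (0.10 log units; within the scatter).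

Compound 4 `COc1ccccc1/C=C1\CCC/C(=C\c2ccc(OC)c(OC)c2)C1=O` is still unmeasured. It differs from compound 3 by this change: 2-methoxyphenyl in place of 3-bromophenyl on a double-bonded chain carbon bound to a double-bonded ring carbon. The 2-methoxyphenyl takes the place of 3-bromophenyl on a double-bonded chain carbon bound to a double-bonded ring carbon.

For the measured compounds named here, no measured step makes this exact swap. The closest match is the 2-chlorophenyl of compound 1, so two steps bear on it: an at least 1.9-fold lower number from compound 1 to compound 2 (0.29 log units; that floor lies within the scatter) and an at least 1.5-fold lower number from compound 1 to compound 3 (0.19 log units; that floor lies within the scatter). Both are only floors, so they offer a weak hint that compound 4 may move towards a higher number, and a result at the limit is possible. The expected change is small, namely a 1.3-fold higher number from compound 3 to compound 4 (0.10 log units; within the scatter). For compound 4 the estimated value is 16000 nM, with an expected range of 7000 nM to 35000 nM.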

Compound 4, half-maximal inhibitory concentration: > 20000 nM
Compound 4: no number, only a limit; the forecaster's own chance of this, stated with the estimate: 40%; at least 1.2-fold (0.09 log units) between middle value and limit.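

Placing 2-methoxyphenyl on this double-bonded chain carbon gives an at least 1.5-fold higher number from compound 3 to compound 4 (0.19 log units; that floor lies within the scatter) and an at least 1.9-fold higher number from compound 2 to compound 4 (0.29 log units; that floor lies within the scatter), so both steps point the same way, though neither floor goes beyond the scatter. The step between compound 1 and compound 4 cannot be read, as both ends are limits. What is new is that a second group named as a 2-substituted phenyl, after the 2-chlorophenyl of compound 1, ends at the same ceiling, while the 4-chlorophenyl of compound 2 and the 3-bromophenyl of compound 3 give numbers: the limit of > 20000 nM in this assay, at which 2 of the 4 values shown sit.

On these data alone, how far compound 1 and compound 4 lie beyond that limit stays unknown, so their two groups cannot be ranked. The compounds shown also leave open whether 3-methoxyphenyl, 4-methoxyphenyl or a phenyl carrying an amine or a carboxylic acid would give a readable number here.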